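The compounds below may be only part of what the source reports. "The series", "measured", "known", "first", "only" and "open" are said of these compounds alone.

Working notes on the series. Compound 3 `CN(C)c1cccc(C(=O)N2CCC(n3cncc3-c3ccc(OS(=O)(=O)c4cccc5cnccc45)cc3)CC2)c1` gives 155 nM in an assay on HEK293 cells for antagonist activity at P2X purinoceptor 7 (Homo sapiens), read by fluorescence, with a stated time of 2 h (on this read-out lower numbers stand for stronger inhibition and higher numbers for weaker inhibition), and sits second highest of the three numbers, with compound 2 `O=C(c1ccc(Oc2ccccc2)cc1)N1CCC(n2cncc2-c2ccc(OS(=O)(=O)c3cccc4cnccc34)cc2)CC1` at 187 nM within the scatter of it and compound 1 `O=C(c1ccc(Cl)c(C(F)(F)F)c1)N1CCC(n2cncc2-c2ccc(OS(=O)(=O)c3cccc4cnccc34)cc2)CC1` at 45 nM clearly lower. Compound 4 `CCN(CC)c1ccc(C(=O)N2CCC(n3cncc3-c3ccc(OS(=O)(=O)c4cccc5cnccc45)cc3)CC2)cc1` carries the change (4-(diethylamino)phenyl in place of 3-(dimethylamino)phenyl on a carbonyl carbon). Among the measured compounds shown here, the only measured step that touches this position is the swap of the aryl on the carbonyl carbon, a 3.4-fold higher number from compound 1 to compound 3 (0.54 log units; beyond the scatter), a modest shift; compound 2 and compound 3 show that two quite different aryl groups there can give near-identical numbers. For compound 4 the expected step in this assay is therefore small, a 1.3-fold higher number from compound 3 to compound 4 (0.11 log units; within the scatter), in either direction or none beyond the scatter. The estimate for compound 4 is 200 nM, expected between 70 nM and 600 nM.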

Compound 4, half-maximal inhibitory concentration: 1440 nM
Compound 4: middle estimate off by 7.2-fold (0.86 log units), on the low side, and the stated range ends below it.
By their numbers in this assay, from the lowest: compound 1; then compounds 3 and 2 (each within the scatter of the next); then compound 4.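

In this assay this position proves far less forgiving than the earlier near-identical aryl groups suggested: the swap gives a 9.3-fold higher number from compound 3 to compound 4 (0.97 log units; beyond the scatter). Diethylamino in place of phenoxy gives a 7.7-fold higher number from compound 2 to compound 4 (0.89 log units; beyond the scatter), and the widest step at this position is a 32-fold higher number from compound 1 to compound 4 (1.51 log units; beyond the scatter). Nothing at hand explains the rise. Compound 4 differs from compound 3 in both the amine chains and their place on the phenyl, and the compounds shown cannot separate the two. Going by these compounds, whether a 4-(dimethylamino)phenyl on the carbonyl carbon would stay close to compound 3 remains open.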